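The source may hold more compounds than are shown below. What is called first, only, known or untested is meant among the compounds shown, and "the series" means these compounds.

Measured so far in an ADME assay on Vero cells (Chlorocebus sabaeus) for inhibition; on this read-out lower numbers stand for higher toxicity in this test and higher numbers for lower toxicity in this test
- compound 1 `COc1ccc(/C=C2\CCC/C(=C\c3ccc(F)cc3)C2=O)cc1` gives 378000 nM
- compound 2 `COc1cccc(/C=C2\CCC/C(=C\c3ccccc3)C2=O)c1OC` gives 33500 nM

Compound 2 holds the lower of the two numbers, beyond the scatter from compound 1. Compound 3 `COc1cccc(/C=C2\CCC/C(=C\c3ccc(F)cc3)C2=O)c1OC` differs from compound 2 by fluoro in place of hydrogen on an aromatic carbon, para to a large group, phenyl to 4-fluorophenyl (fluoro in place of hydrogen on an aromatic carbon). Within the data shown here, no measured pair isolates this change. Compound 1, which also carries the 4-fluorophenyl but differs elsewhere too, gives 378000 nM and so points weakly upward. A modest rise in this assay is expected, estimated as a 1.8-fold higher number from compound 2 to compound 3 (0.25 log units; within the scatter) and close to the scatter. Compound 3 is estimated at 60000 nM (expected range 20000 nM to 200000 nM).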

Compound 3, half-maximal cytotoxic concentration: 33200 nM
The estimate for compound 3 lay 1.8-fold (0.26 log units) above the measured number, and the stated range covers the measured number.
By their numbers in this assay, from the lowest: compounds 3 and 2 (each within the scatter of the next); then compound 1.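

Fluoro in place of hydrogen, on an aromatic carbon para to a large group, is now isolated by a single pair: in this assay the step reads a 1.0-fold lower number from compound 2 to compound 3 (0.00 log units; within the scatter) and the two compounds cannot be told apart. On this core, phenyl and 4-fluorophenyl are therefore equivalent in this read-out. No available evidence bears on this result.

Still open, on these data alone, is whether an amine or a carboxylic acid at this position would shift the read-out. Also open is whether the same change behaves alike on the core of compound 1, where only the 4-fluorophenyl form is shown.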